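From 2-chloroethoxy to (3-chloroprop-2-en-1-yl)oxy

The source may report more compounds than this note shows. Statements on the series, on what has been measured and on what is new or still open speak of the compounds shown alone.

Of the compounds shown here, three sharing one core have been measured in a physicochemical assay for lipophilicity, measured as octanol-water partition; a lower number here means a more polar compound, a higher number a more lipophilic compound. Compound 1 (`C#CCc1c(Cl)cc(N/C=N/OCC=C)cc1Cl`), with vinyl on a saturated chain carbon bound to an oxygen, gives 3.7. Compound 2 (`C#CCc1c(Cl)cc(N/C=N/OCC(=O)OCC)cc1Cl`), with ethoxycarbonyl there, gives 3.6. Compound 3 (`C#CCc1c(Cl)cc(N/C=N/OCCCl)cc1Cl`), with chloromethyl there, gives 3.7. Compound 3 thus stands level with compound 1 at the digits shown, and all three lie within the scatter of one another.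

Compound 4 (`C#CCc1c(Cl)cc(N/C=N/OC/C=C/Cl)cc1Cl`) has not yet been measured. It carries 2-chloroethenyl in place of the chloromethyl of compound 3 (2-chloroethenyl in place of chloromethyl on a saturated chain carbon bound to an oxygen), which brings in 1 double bond outside aromatic rings. Three measured swaps at the same place bear on this. Vinyl to chloromethyl gave no change at the digits printed from compound 1 to compound 3 (within the scatter), vinyl to ethoxycarbonyl gave a number 0.10 log units lower from compound 1 to compound 2 (within the scatter), and ethoxycarbonyl to chloromethyl gave a number 0.10 log units higher from compound 2 to compound 3 (within the scatter). Going by the values given here, none of them is this change, and no measured compound shows a chlorine and a double bond together in this group, so the direction is a judgement. All three steps were small, so only a modest rise in this assay is expected, namely a number 0.30 log units higher from compound 3 to compound 4 (within the scatter). The estimate for compound 4 is 4, with an expected range from 3.7 to 4.4.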

Compound 4, partition coefficient: 3.9
Compound 4: the middle estimate sits 0.10 log units above what was measured, and the stated range covers the measured number.
By their numbers in this assay, from the lowest: compounds 2, 1, 3 and 4 (each within the scatter of the next).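

In this assay, 2-chloroethenyl, the only group shown that holds a chlorine and a double bond together on a saturated chain carbon bound to an oxygen, gives a number 0.20 log units higher from compound 3 to compound 4 (within the scatter) and a number 0.20 log units higher from compound 1 to compound 4 (within the scatter) and also a number 0.30 log units higher from compound 2 to compound 4 (within the scatter) in this set. This extends the picture at this place from three groups to four, and even the pair furthest apart in these numbers, the 2-chloroethenyl and ethoxycarbonyl compounds, is still printed as within the scatter, so none of the four can be placed above or below another. Nothing measured here explains the size of any of these steps or separates the part played by the chlorine from that of the double bond.

As far as these compounds go, what a charged or strongly hydrogen-bonding group such as an amine or a carboxylic acid would give on this saturated chain carbon stays open, as does the outcome for a longer chain carrying the chlorine further out. From the compounds shown here alone, all four compounds also share one core and one read-out, so whether 2-chloroethenyl and chloromethyl stay this close on another core, or in any other assay, remains unknown.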